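The source may hold more compounds than are shown below. What is called first, only, known or untested is meant among the compounds shown, and "the series" means these compounds.

Compound 1 `COc1ccc(C2=C(c3ccc(SC)cc3)CC3CCCN3C2=O)cc1OC(=O)C1CCCN1C(=O)OC(C)(C)C` gives 5000 nM in a functional assay on NCI-H520 cells (Homo sapiens) for cytotoxicity; on this read-out higher numbers stand for weaker inhibition of growth and lower numbers for stronger inhibition of growth.
Compound 2 `CSc1ccc(C2=C(c3ccc(C)c(C)c3)C(=O)N3CCCC3C2)cc1` gives 300 nM in this assay.
Compound 3 `CSc1ccc(C2=C(c3ccc(Br)cc3)C(=O)N3CCCC3C2)cc1` gives 7000 nM in this assay.

Compound 2 holds the lowest number of the three; compound 1 and compound 3 both sit beyond the scatter from it. Compound 4 `CSc1ccc(C2=C(c3ccc(SC)cc3)C(=O)N3CCCC3C2)cc1` has not yet been measured. It differs from compound 2 in one place: 4-(methylsulfanyl)phenyl in place of 3,4-dimethylphenyl on a double-bonded ring carbon. Among the compounds with values here, the one measured step at the same position is a 23-fold higher number from compound 2 to compound 3 (1.37 log units; beyond the scatter), a large weakening. In compound 3 a 4-bromophenyl replaced the 3,4-dimethylphenyl; in compound 4 a 4-(methylsulfanyl)phenyl replaces it, so a weakening is expected here as well, though its size is uncertain. Compound 4 is therefore estimated to give 2500 nM (range 600 nM to 10000 nM), an expected step of an 8.3-fold higher number from compound 2 to compound 4 (0.92 log units; beyond the scatter) in this assay.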

Compound 4, concentration for 50% growth inhibition: 15000 nM
For compound 4 the middle estimate is 6.0-fold (0.78 log units) below the measured one; measured number above the stated range.
By their numbers in this assay, from the lowest: compound 2; then compounds 1 and 3 (each within the scatter of the next); then compound 4.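

In this assay, the step of a 50-fold higher number from compound 2 to compound 4 (1.70 log units; beyond the scatter) shows that 3,4-dimethylphenyl outperforms not one but two replacements on the double-bonded ring carbon, 4-bromophenyl and 4-(methylsulfanyl)phenyl. Methylsulfanyl in place of bromo on the aromatic carbon gives a 2.1-fold higher number from compound 3 to compound 4 (0.33 log units; beyond the scatter), a modest step that is still beyond the scatter. No supporting measurement explains either step. The compounds shown leave open whether both methyl groups of compound 2 are needed, and how a 4-methylphenyl or a phenyl carrying an amine would behave at this position.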